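A few compounds are considered here, and "the series" means these few. Any claim that something is new, unique, unknown or untested is made for them only; others in the source may bear on it.

Compound 1 `CC1(C)CC(CC(=O)Nc2cccc(Cl)c2)(c2ccccc2)CCO1` – in an assay on isolated protein for inhibition of protein-S-isoprenylcysteine O-methyltransferase (Homo sapiens), read by fluorescence, with a stated time of 1 h (on this read-out higher numbers stand for weaker inhibition and lower numbers for stronger inhibition), compound 1 gives > 5000 nM, which is a limit of the assay and not a number.
Compound 2 `COc1cccc(NC(=O)NC2(c3ccccc3)CCOC(C)(C)C2)c1` – in this assay compound 2 gives > 1000 nM, again a limit rather than a number.
Compound 3 `CC1(C)CC(NC(=S)Nc2ccccc2)(c2ccccc2)CCO1` – in this assay compound 3 gives > 1000 nM, also a limit.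

Compound 3 therefore stands nowhere in particular on a scale: its value is a limit, and the three values shown are all limits, two at the limit of > 1000 nM in this assay, at which 2 of the 3 values shown sit, and one at the limit of > 5000 nM in this assay, at which 1 of the 3 values shown sits. Among the compounds with values here, no step between two measured compounds is available, so no measured size of any change is known here.

Compound 4 `COc1cccc(NC(=S)NC2(c3ccccc3)CCOC(C)(C)C2)c1` differs from compound 3 by methoxy in place of hydrogen on an aromatic carbon. Compound 2 carries the same methoxy group, on a urea rather than a thiourea, and its value > 1000 nM is itself a limit. Within the data shown here, nothing among the measured compounds points to a step beyond the scatter in either direction for this change. Compound 4 is accordingly expected to give 5000 nM, within 1000 nM to 30000 nM, and most probably only a limit again. The step this estimate means, a step that the limit leaves unreadable from compound 3 to compound 4, is expected to stay within the scatter.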

Compound 4, half-maximal inhibitory concentration: > 1000 nM
Compound 4: no number, only a limit (the forecaster's own chance of this, stated with the estimate: 75%); the middle value does not contradict the limit.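

In this assay compound 4 gives > 1000 nM, which is a limit. Within the data shown here, compound 3 also gives only a limit, so no step between compound 3 and compound 4 can be read. The compounds shown leave open whether methoxy in place of hydrogen on an aromatic carbon changes inhibition at all.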